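N-Methylation of the primary amide in a sulfonamide series

This account rests on a few compounds, and the source may have more. Where it says the series, first, only, none or still open, it means among the compounds named here.

Measured so far:
compound 1, `COC(=O)c1cncc(NS(=O)(=O)c2cc(Cl)ccc2OC)c1`, gives 65 nM in an assay on isolated protein for inhibition of alkaline phosphatase, tissue-nonspecific isozyme (Homo sapiens); a higher number here means a weaker inhibitor, a lower number a stronger inhibitor
compound 2, `COc1ccc(Cl)cc1S(=O)(=O)Nc1cncc(C(N)=O)c1`, gives 16 nM in this assay
compound 3, `COc1ccc(OC(F)(F)F)cc1S(=O)(=O)Nc1cncc(C(N)=O)c1`, gives 131 nM in this assay

Compound 2 gives the lowest number of the three. The nearest is compound 1, which differs by a 4.1-fold lower number from compound 1 to compound 2 (0.61 log units; beyond the scatter), and the furthest is compound 3, which differs by an 8.2-fold higher number from compound 2 to compound 3 (0.91 log units; beyond the scatter). Both steps are beyond the scatter and both are modest in size.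

Compound 4, `CNC(=O)c1cncc(NS(=O)(=O)c2cc(Cl)ccc2OC)c1`, differs from compound 2 only in one spot: methyl in place of hydrogen on an amide-type nitrogen. Cut one bond further out, the change reads amino to methylamino, carbamoyl to methylcarbamoyl. Within the data shown here, no measured pair shows this exact change. The step that bears on it most closely is the one on the same carbonyl carbon, where methoxy became amino and gave the modest change a 4.1-fold lower number from compound 1 to compound 2 (0.61 log units; beyond the scatter). Compound 4 carries a methylamino group that stands between methoxy and amino in its make-up, so a step of comparable size, back toward a higher number, is expected, though a change within the scatter cannot be excluded. Compound 4 is therefore estimated at 35 nM, with a range from 12 nM to 110 nM, which means the expected step of a 2.2-fold higher number from compound 2 to compound 4 (0.34 log units; beyond the scatter).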

Compound 4, half-maximal inhibitory concentration: 109 nM
For compound 4 the middle estimate is 3.1-fold (0.49 log units) below the measured one; measured number inside the range.
By their numbers in this assay, from the lowest: compound 2; then compounds 1, 4 and 3 (each within the scatter of the next).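

In this assay, methyl in place of hydrogen on the amide-type nitrogen gives a 6.8-fold higher number from compound 2 to compound 4 (0.83 log units; beyond the scatter) and so shows that this nitrogen does not take the added methyl without a loss. The change from methoxy to methylamino on the same carbonyl carbon gives a 1.7-fold higher number from compound 1 to compound 4 (0.22 log units; within the scatter) and leaves those two groups unseparated, so among the three groups shown on this carbon, only the amino group of compound 2 gives the lower number. No measurement available here accounts for this difference.

Going by these compounds, it remains open whether an ethyl group or a second methyl on this nitrogen would move the number further, and how a carboxylic acid at this place would compare. On these data alone, it is also open whether the methyl step would carry over with trifluoromethoxy in place of chloro, as in compound 3.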